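From acetoxy to hydroxy on a shared core

The source may hold more compounds than are shown below. What is called first, only, known or untested is meant among the compounds shown, and "the series" means these compounds.

Three compounds sharing a core have entries in an ADME assay on HEK293 cells (Homo sapiens) for cytotoxicity, read by MTT assay, with a stated time of 72 h; on this read-out lower numbers stand for stronger inhibition and higher numbers for weaker inhibition. Compound 1 `COc1ccc(C2=C(c3cc(OC)c(OC)c(OC)c3)C(=O)C(OC(C)=O)C2)cc1OC(C)C` gives > 100 ug/mL, which is a limit and not a number. Compound 2 `COc1ccc(C2=C(c3cc(OC)c(OC)c(OC)c3)C(=O)CC2C)cc1C(=O)O` gives > 100 ug/mL, again a limit and not a number. Together these two make up (the limit of > 100 ug/mL in this assay, at which 2 of the 3 values shown sit). Compound 3 `COc1ccc(C2=C(c3cc(OC)c(OC)c(OC)c3)C(=O)C(OC(C)=O)C2)cc1` has no number at all, its entry reading "not determined" (no result reported), so it cannot be placed on the scale.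

Compound 4 `COc1ccc(C2=C(c3cc(OC)c(OC)c(OC)c3)C(=O)C(O)C2)cc1` comes from compound 3 by a single change, hydrogen in place of acetyl on an oxygen on a saturated carbon: acetoxy to hydroxy, with hydrogen in place of acetyl on an oxygen on a saturated carbon. Among the compounds with values here, no measured step shows what this change does, and compound 3 offers no number to start from. No step beyond the usual scatter is therefore expected in this assay, in either direction. This expectation rests on compound 1, whose result is the limit > 100 ug/mL. Compound 4 is expected near 100 ug/mL, with an estimated range from 30 ug/mL to 200 ug/mL, and it may well be reported only as a limit.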

Compound 4, half-maximal inhibitory concentration: 6.3 ug/mL
Estimate against measurement, compound 4: 16-fold (1.20 log units) above; the whole stated range lies above it.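

In this assay, within the data shown here, compound 4 gives 6.3 ug/mL but compound 3 has no number, so no step from acetoxy to hydroxy can be read between these two compounds. Nothing shown accounts for this value. The compounds shown leave open what the change from acetoxy to hydroxy does on the shared core.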